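The compounds below may be only part of what the source reports. "The series", "measured", "known", "first", "only" and "open" are said of these compounds alone.

Working notes on the cinnamate ester series

Compound 1 `COc1ccc(OC(=O)c2nc(C)c(C)nc2C)c(/C=C/C(=O)O)c1` carries the free acid on a core of its own; in a functional assay on EA.hy 926 cells (Homo sapiens) for cytotoxicity, read by MTT assay, with stated times of 24 h and 12 h, tested at 12.5 uM (a higher number here means a stronger effect of the compound at the concentration tested, a lower number a weaker effect), compound 1 gives 21.7%. Compound 2 `COc1ccc(/C=C/C(=O)O)cc1OC(=O)c1nc(C)c(C)nc1C` is built from the same atoms joined differently, and in this assay compound 2 gives 41.3%. The difference between the two cores is not broken down here; the two values alone show compound 2 with the higher number, and the gap between them lies beyond the scatter.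

Compound 3 `CCOC(=O)/C=C/c1ccc(OC)c(OC(=O)c2nc(C)c(C)nc2C)c1` is the ethyl ester of compound 2, the change being (ethyl in place of hydrogen on an oxygen next to a carbonyl group). In this assay compound 3 gives 26.4%, which is a number 14.9 percentage points lower from compound 2 to compound 3 (beyond the scatter). The value of compound 3 and the value of compound 1 lie within the scatter of each other.

For the measured compounds named here, compound 4 `CCOC(=O)/C=C/c1cc(OC)ccc1OC(=O)c1nc(C)c(C)nc1C` stands to compound 1 as compound 3 stands to compound 2: the change is ethyl in place of hydrogen on an oxygen next to a carbonyl group, the same change, at the same place, as the one from compound 2 to compound 3. Going by the values given here, whether the change carries over from one core to the other is not yet known; only one measured pair shows it.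

On the expectation that the step repeats, compound 4 is estimated at 12%, a step of a number 9.7 percentage points lower from compound 1 to compound 4 (within the scatter) set beside the earlier one, because the earlier change gave a number 14.9 percentage points lower from compound 2 to compound 3 (beyond the scatter). The estimate for compound 4 is expected to fall between 2% and 26%, the lower bound being held up by the floor of the read-out.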

Compound 4, a percentage reported as activity, at one concentration (the size of the read-out at that concentration, not a potency): 15.9%
Compound 4: the middle estimate sits 3.9 percentage points below what was measured; the range from low to high includes it.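

In this assay the change from carboxy to ethoxycarbonyl gives a number 5.8 percentage points lower from compound 1 to compound 4 (within the scatter), so on this core the ethyl ester and the free acid cannot be told apart. Set beside the same change on the other core, the new step does not differ from the earlier one: the same change on two cores in this assay, a number 14.9 percentage points lower (beyond the scatter) from compound 2 to compound 3 and a number 5.8 percentage points lower (within the scatter) from compound 1 to compound 4, 9.1 percentage points apart, within the scatter of two such steps This shows that the two pairs give no sign of the change behaving differently on the two cores, but it does not show that the step has a fixed size that can be carried from one core to another, as only one of the two steps lies beyond the scatter and two pairs are too few to support a rule for any further core.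

The compounds shown cover only hydrogen and ethyl at this place on the carboxyl oxygen, so it remains open how a methyl ester, a longer chain such as a butyl ester, or an amide formed with an amine would read on either core. Only one concentration and one cell line are shown, and how the step behaves under other conditions also stays open.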